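Alkynyl hydrazone sulfonylguanidines against MCF7: benzyl and naphthylmethyl thioethers

The source may hold more compounds than are shown below. What is called first, only, known or untested is meant among the compounds shown, and "the series" means these compounds.

Measured so far:
compound 1, `Cc1cc(S(=O)(=O)/N=C(\N)N/N=C/C#Cc2ccccc2)c(SCc2ccc(Cl)cc2)cc1Cl`, in a functional assay on MCF7 cells (Homo sapiens) for antiproliferative activity, read by MTT assay, with a stated time of 72 h (a higher number here means a weaker inhibitor, a lower number a stronger inhibitor), compound 1 gives 18000 nM
compound 2, `C/C(C#Cc1ccccc1)=N\N/C(N)=N/S(=O)(=O)c1cc(C)c(Cl)cc1SCc1ccc(Cl)cc1`, in this assay compound 2 gives 14000 nM
compound 3, `Cc1cc(S(=O)(=O)/N=C(\N)N/N=C/C#Cc2ccccc2)c(SCc2cccc3ccccc23)cc1Cl`, in this assay compound 3 gives 22000 nM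

All three measured numbers sit within the scatter of one another, so no order among them is claimed. The change from compound 1 to compound 2 is a group of 11 heavy atoms (10 carbon, 1 nitrogen; one six-membered aromatic ring of carbon only) in place of a group of 10 heavy atoms (9 carbon, 1 nitrogen; one six-membered aromatic ring of carbon only), on an amine nitrogen; it made a step of a 1.3-fold lower number from compound 1 to compound 2 (0.11 log units; within the scatter). The two cores differ as naphthalen-1-yl in place of 4-chlorophenyl on a saturated chain carbon bound to a sulfur, and that change made a step of a 1.2-fold higher number from compound 1 to compound 3 (0.09 log units; within the scatter).

Compound 4, `C/C(C#Cc1ccccc1)=N\N/C(N)=N/S(=O)(=O)c1cc(C)c(Cl)cc1SCc1cccc2ccccc12`, is not yet measured. It differs from compound 3 by a group of 11 heavy atoms (10 carbon, 1 nitrogen; one six-membered aromatic ring of carbon only) in place of a group of 10 heavy atoms (9 carbon, 1 nitrogen; one six-membered aromatic ring of carbon only), on an amine nitrogen, the same change as from compound 1 to compound 2, made on the same kind of place. Going by the values given here, compound 4 is therefore expected to show a step of about a 1.3-fold lower number from compound 3 to compound 4 (0.11 log units; within the scatter), resting on the single earlier instance, a 1.3-fold lower number from compound 1 to compound 2 (0.11 log units; within the scatter), which lay within the scatter. Compound 4 is estimated at 17000 nM in this assay, with a range of 9000 nM to 34000 nM.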

Compound 4, half-maximal inhibitory concentration: 210000 nM
Compound 4: the middle estimate sits 12-fold (1.09 log units) below what was measured; measured number above the stated range.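

In this assay, the group of 11 heavy atoms in place of the group of 10 heavy atoms on the amine nitrogen gave a 9.5-fold higher number from compound 3 to compound 4 (0.98 log units; beyond the scatter), and naphthalen-1-yl in place of 4-chlorophenyl gave a 15-fold higher number from compound 2 to compound 4 (1.18 log units; beyond the scatter). The change on the amine nitrogen did not carry from one core to the other at its earlier size: the same change on two cores in this assay, a 1.3-fold lower number (0.11 log units; within the scatter) from compound 1 to compound 2 and a 9.5-fold higher number (0.98 log units; beyond the scatter) from compound 3 to compound 4, 12-fold (1.09 log units) apart, beyond the scatter of two such steps. The change on the saturated chain carbon bound to a sulfur likewise depended on the core, so the two changes do not simply add in compound 4, though these four compounds form a single set and do not show why the two groups behave differently together: the same change on two cores in this assay, a 1.2-fold higher number (0.09 log units; within the scatter) from compound 1 to compound 3 and a 15-fold higher number (1.18 log units; beyond the scatter) from compound 2 to compound 4, 12-fold (1.09 log units) apart, beyond the scatter of two such steps.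

Going by these compounds, it remains open whether the weaker result of compound 4 is particular to naphthalen-1-yl or would recur with another group on that chain carbon, such as an unsubstituted phenyl or a 4-methoxyphenyl. A longer alkyl chain in the group on the amine nitrogen also remains untested among the compounds shown here.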